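A few compounds are considered here, and "the series" means these few. Any claim that something is new, unique, unknown or untested is made for them only; others in the source may bear on it.

Working notes on the series. Compound 1 is `CS(=O)(=O)Nc1ccc2c(c1)S(=O)(=O)N=C(C1=C(O)C3CCCC3N(CCC3CC3)C1=O)N2`, compound 2 is `CS(=O)(=O)Nc1ccc2c(c1)S(=O)(=O)N=C(C1=C(O)C3CCCC3N(C3CCCCC3)C1=O)N2` and compound 3 is `CS(=O)(=O)Nc1ccc2c(c1)S(=O)(=O)N=C(C1=C(O)C3CCCC3N(Cc3ccc(Cl)cc3)C1=O)N2`; they share one core and differ only in the group on the amide-type nitrogen in the ring. In an ADME assay on Huh-7 cells (Homo sapiens) for cytotoxicity, with a stated time of 72 h (a higher number here means that more compound is tolerated, a lower number that less compound is tolerated), compound 1 gives > 33000 nM, which is a limit of the assay and not a number. In this assay compound 2 gives > 10000 nM, likewise a limit. In this assay compound 3 gives > 10000 nM, again a limit. Compound 3 thus stands on a limit, and the two further values shown are limits as well. The measured steps are accordingly unreadable: a step that the two limits leave unreadable from compound 1 to compound 2, a step that the two limits leave unreadable from compound 1 to compound 3 and a step that the two limits leave unreadable from compound 2 to compound 3. What the values do show is the limit of > 10000 nM in this assay, at which 2 of the 3 values shown sit, and (the limit of > 33000 nM in this assay, at which 1 of the 3 values shown sits). Compound 4 is `CCN1C(=O)C(C2=NS(=O)(=O)c3cc(NS(C)(=O)=O)ccc3N2)=C(O)C2CCCC21`; it differs from compound 3 by methyl in place of 4-chlorophenyl on a saturated chain carbon bound to an amide-type nitrogen in a ring. Within the data shown here, no measured step gives a readable size for a change at this place, but each of the three groups tried on that nitrogen left the value at a limit. For compound 4 the step from compound 3 is therefore expected to be a step that the limit leaves unreadable from compound 3 to compound 4, none beyond the scatter. Compound 4 is estimated at 20000 nM, with a range from 8000 nM to 50000 nM, and most probably will again be reported only as a limit.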

Compound 4, half-maximal cytotoxic concentration: > 33000 nM
Compound 4 was reported as a limit (the forecaster's own chance of this, stated with the estimate: 80%); at least 1.6-fold (0.21 log units) between middle value and limit.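

In this assay compound 4 gives > 33000 nM, a limit of the assay and not a number. Its steps from compound 1, compound 2 and compound 3 therefore cannot be read. The compounds shown leave open whether any group on the amide-type nitrogen in the ring changes the tolerated concentration at all, and by how much.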